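A few compounds are considered here, and "the series" means these few. Any claim that something is new, unique, unknown or untested is made for them only; others in the source may bear on it.

Compound 1 `CCN(CC)Cc1ccc2nc(NC(=O)N/N=C/c3cn(Cc4ccc(C(C)(C)C)cc4)c4ccccc34)sc2c1` is the reference point here. Among the compounds with values here, in a functional assay on A549 cells (Homo sapiens) for cytotoxicity, read by MTT assay, with a stated time of 72 h (on this read-out higher numbers stand for weaker inhibition and lower numbers for stronger inhibition), compound 1 gives 1710 nM, the lowest of the three numbers known so far, though its neighbours sit close: compound 3 `CN(C)Cc1ccc2nc(NC(=O)N/N=C/c3cn(Cc4ccc(C(C)(C)C)cc4)c4ccccc34)sc2c1` gives 1850 nM, and compound 2 `CN(C)Cc1ccc2nc(NC(=O)N/N=C3\C(=O)Nc4ccc(Cl)cc43)sc2c1` gives 3180 nM, both within the scatter of compound 1. The step of a 1.1-fold higher number from compound 1 to compound 3 (0.03 log units; within the scatter) shows that swapping one small amine for another at the shared core left the read-out essentially untouched.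

Compound 4 `CCN(CC)Cc1ccc2nc(NC(=O)N/N=C/c3cn(Cc4ccccc4Cl)c4ccccc34)sc2c1` is the next question. It differs from compound 1 by 2-chlorophenyl in place of 4-(tert-butyl)phenyl on a saturated chain carbon bound to an aromatic nitrogen. Within the data shown here, no measured step touches this part of the molecule, so the only guide is that the single known change elsewhere did nothing beyond scatter. A step of a 1.5-fold higher number from compound 1 to compound 4 (0.16 log units; within the scatter) is therefore expected, with compound 4 estimated at 2500 nM (range 900 nM to 7000 nM).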

Compound 4, half-maximal inhibitory concentration: 1390 nM
Compound 4: the middle estimate sits 1.8-fold (0.25 log units) above what was measured; the measured number falls inside the stated range.
By their numbers in this assay, from the lowest: compounds 4, 1, 3 and 2 (each within the scatter of the next, the first and the last beyond it).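

Within the data shown here, this is the first change at the group on the saturated chain carbon bound to an aromatic nitrogen, and in this assay the step is small: a 1.2-fold lower number from compound 1 to compound 4 (0.09 log units; within the scatter). Thus 2-chlorobenzyl, with fewer heavy atoms and a chlorine, serves as well as 4-(tert-butyl)benzyl on this read-out. No measurement here offers an explanation for this result. Still open, from the compounds shown here alone, is whether a benzyl carrying an amine or a carboxylic acid would keep the number in this range. A longer chain between the aromatic nitrogen and the benzene ring also remains untested among the compounds shown.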